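The source may hold more compounds than are shown below. What is called first, only, known or untested is meant among the compounds shown, and "the series" means these compounds.

- compound 1 `CC[C@H](NC(=O)[C@H](COC)NC(=O)c1cc(C)on1)C(=O)N[C@@H](CC(C)C)C(=O)[C@@]1(C)CO1` gives 100%
- compound 2 `COC[C@H](NC(=O)c1cc(C)on1)C(=O)N[C@@H](CC1CCCCC1)C(=O)N[C@@H](CC(C)C)C(=O)[C@@]1(C)CO1` gives 75%

In a physicochemical assay for metabolic stability, in simulated intestinal fluid, with a stated time of 15 min, tested at 4 uM (on this read-out higher numbers stand for a more stable compound and lower numbers for a less stable compound), compound 2 is the lower of the two measured compounds, at 75%. Compound 3 `COC[C@H](NC(=O)c1cc(C)on1)C(=O)N[C@@H](CC(C)C)C(=O)N[C@@H](CC(C)C)C(=O)[C@@]1(C)CO1` has isopropyl in place of cyclohexyl on a saturated chain carbon, two bonds along the chain from an amide-type nitrogen and a carbonyl carbon. Among the measured compounds shown here, the only measured step at this place, cyclohexyl in place of methyl, is modest and beyond the scatter (a number 25 percentage points lower from compound 1 to compound 2 (beyond the scatter)). The new change runs partly back along that step, so a smaller upward step in this assay is expected (a number 10 percentage points higher from compound 2 to compound 3 (within the scatter)). The estimated value for compound 3 is 85%, with an expected range of 70% to 100%.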

Compound 3, percent of the compound remaining: 90%
Estimate against measurement, compound 3: 5 percentage points below; measured number inside the range.
By their numbers in this assay, from the lowest: compound 2; then compounds 3 and 1 (each within the scatter of the next).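

At this place on a saturated chain carbon, in this assay, the cyclohexyl of compound 2 is not needed for the change in the number: the smaller, ring-free isopropyl gives a number 15 percentage points higher from compound 2 to compound 3 (beyond the scatter). Set against methyl, isopropyl gives a number 10 percentage points lower from compound 1 to compound 3 (within the scatter), so of these three compounds only compound 2 stands apart, beyond the scatter from both others. Nothing available explains this difference.

Open, going by these compounds, is whether the ring or the count of carbons goes with the lower number for compound 2. Also open, on these data alone, is how a straight butyl chain or an amine would read at this place in this assay.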